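Cytotoxicity of a salicylanilide series: from isopropylamino to pyridinylmethylamino

A few compounds are considered here, and "the series" means these few. Any claim that something is new, unique, unknown or untested is made for them only; others in the source may bear on it.

Measured compounds and their values in an ADME assay on A549 cells (Homo sapiens) for cytotoxicity, read by resazurin assay, with a stated time of 48 h; on this read-out lower numbers stand for higher toxicity in this test and higher numbers for lower toxicity in this test:
- compound 1 `CC(C)Nc1ccc(NC(=O)c2cc(Cl)ccc2O)c(Cl)c1` gives 11000 nM
- compound 2 `CCN(CC)c1ccc(NC(=O)c2cc(Cl)ccc2O)c(Cl)c1` gives 55500 nM
- compound 3 `O=C(Nc1ccc(NCc2ccc(Br)cc2)cc1Cl)c1cc(Cl)ccc1O` gives 40900 nM

Compound 1 has the lowest number of the three in this assay, meaning it is the most toxic compound measured here; its nearest neighbour is compound 3 and the furthest is compound 2. The unmeasured compound 4 `O=C(Nc1ccc(NCc2ccncc2)cc1Cl)c1cc(Cl)ccc1O` differs from compound 1 in one place: (pyridin-4-yl)methyl in place of isopropyl on a nitrogen on an aromatic ring.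

Within the data shown here, two measured steps bear on this change, both leaving the isopropylamino group of compound 1 for a larger substituent on the same nitrogen or carbon: a 5.0-fold higher number from compound 1 to compound 2 (0.70 log units; beyond the scatter) and a 3.7-fold higher number from compound 1 to compound 3 (0.57 log units; beyond the scatter). Between those two larger groups the values are close, as a 1.4-fold lower number from compound 2 to compound 3 (0.13 log units; within the scatter) shows. Compound 4 carries a benzyl-like group most similar to that of compound 3, so a modest rise in the number in this assay is expected, beyond the scatter but not large. The estimate for compound 4 is 32000 nM, with a range of 11000 nM to 90000 nM, which corresponds to an expected step of a 2.9-fold higher number from compound 1 to compound 4 (0.46 log units; beyond the scatter).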

Compound 4, half-maximal cytotoxic concentration: 65300 nM
The estimate for compound 4 lay 2.0-fold (0.31 log units) below the measured number; the range from low to high includes it.
By their numbers in this assay, from the lowest: compound 1; then compounds 3, 2 and 4 (each within the scatter of the next).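

In this assay, (pyridin-4-yl)methyl in place of isopropyl on a nitrogen on an aromatic ring gives a 5.9-fold higher number from compound 1 to compound 4 (0.77 log units; beyond the scatter), so a six-membered aromatic ring with a hetero atom is tolerated here without a return to the lowest number of the series. Exchanging 4-bromophenyl for pyridin-4-yl gives a 1.6-fold higher number from compound 3 to compound 4 (0.20 log units; within the scatter), and ((pyridin-4-yl)methyl)amino in place of diethylamino gives a 1.2-fold higher number from compound 2 to compound 4 (0.07 log units; within the scatter), both within the scatter, so the three non-isopropyl compounds cannot be told apart and only the isopropylamino compound stands apart. Nothing available explains this difference.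

As far as these compounds go, it remains open whether a methyl or an unsubstituted amine at this place would group with the isopropylamino compound or with the other three. Also open, from the compounds shown here alone, is whether a (pyridin-2-yl)methyl or a plain benzyl would match the (pyridin-4-yl)methyl result.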